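The compounds below may be only part of what the source reports. "The series", "measured", "known", "first", "only" and "open" are said of these compounds alone.

The three compounds measured in a functional assay on B16-F10 cells (Mus musculus) for antiproliferative activity, read by MTT assay, with a stated time of 48 h (a lower number here means a stronger inhibitor, a higher number a weaker inhibitor), are:

Compound 1 `COc1ccc(-c2cn3cc(C4=CCN(C(=O)c5cccc(C(F)(F)F)c5)CC4)ccc3n2)cc1OC` gives 7890 nM.
Compound 2 `COc1ccc(-c2cn3cc(C4=CCN(S(=O)(=O)C5CCCC5)CC4)ccc3n2)cc1OC` gives 7690 nM.
Compound 3 `COc1ccc(-c2cn3cc(C4=CCN(S(=O)(=O)CCc5ccccc5)CC4)ccc3n2)cc1OC` gives 8080 nM.

All three share one core and differ only in the group on an amine nitrogen in a ring. Compound 2 has the lowest of the three numbers, yet its steps to the others, a 1.0-fold lower number from compound 1 to compound 2 (0.01 log units; within the scatter) and a 1.1-fold higher number from compound 2 to compound 3 (0.02 log units; within the scatter), are both within the scatter, so the three cannot be told apart.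

Compound 4 `COc1ccc(-c2cn3cc(C4=CCN(C(=O)C5CCCCC5)CC4)ccc3n2)cc1OC` is not yet measured. The change from compound 2 is cyclohexylcarbonyl in place of cyclopentylsulfonyl on an amine nitrogen in a ring. For the measured compounds named here, two measured steps bear on it: the swap of a carbonyl for a sulfonyl at the same place, a 1.0-fold lower number from compound 1 to compound 2 (0.01 log units; within the scatter), and the swap of cyclopentyl for phenethyl on the sulfonyl, a 1.1-fold higher number from compound 2 to compound 3 (0.02 log units; within the scatter), both within the scatter. Exchanging a ring attached through a sulfonyl for a ring attached through a carbonyl is therefore expected to move the number little, if at all, in this assay.

Compound 4 is thus estimated at 7800 nM, with a range of 4000 nM to 16000 nM, an expected step of a 1.0-fold higher number from compound 2 to compound 4 (0.01 log units; within the scatter).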

Compound 4, half-maximal inhibitory concentration: 10900 nM
Estimate against measurement, compound 4: 1.4-fold (0.15 log units) below, and the stated range covers the measured number.
By their numbers in this assay, from the lowest: compounds 2, 1, 3 and 4 (each within the scatter of the next).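

At this amine nitrogen in a ring, this assay still does not separate the groups: the steps of a 1.4-fold higher number from compound 2 to compound 4 (0.15 log units; within the scatter), a 1.3-fold higher number from compound 3 to compound 4 (0.13 log units; within the scatter) and a 1.4-fold higher number from compound 1 to compound 4 (0.14 log units; within the scatter) are all within the scatter. For the compounds shown here, the last step is the first to hold the carbonyl fixed and change only what it carries, and replacing an aromatic ring bearing trifluoromethyl with cyclohexyl does not give a clear change. No measurement is available to explain these results.

Still open, on these data alone, is whether a different kind of group on this nitrogen, such as a chain ending in an amine or a carboxylic acid, would give a step beyond the scatter. The compounds shown also all keep the same core, so they say nothing about how changes elsewhere in the molecule would affect the number.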